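A few compounds are considered here, and "the series" means these few. Any claim that something is new, unique, unknown or untested is made for them only; others in the source may bear on it.

Measured compounds:
`Clc1ccccc1CO/N=C/c1c(-c2ccc3ccccc3c2)nc2occn12` compound 1: 1100 nM
`Clc1ccc(CO/N=C/c2c(-c3ccc(C4CCCCC4)cc3)nc3sccn23)cc1Cl` compound 2: > 100000 nM

Among the measured compounds shown here, in an assay on HepG2 cells for agonist activity at nuclear receptor subfamily 1 group I member 3 (Homo sapiens), read by a luciferase reporter, with a stated time of 23 h (on this read-out lower numbers stand for an effect already at smaller amounts and higher numbers for an effect only at larger amounts of compound), compound 1 gives 1100 nM, the only real number among the two values shown. For compound 2 the assay gives only a limit, (the limit of > 100000 nM in this assay, at which 1 of the 2 values shown sits), and no number. Compound 3, `CC(C)(C)c1ccc(CO/N=C/c2c(-c3ccc4ccccc4c3)nc3occn23)cc1`, is not yet measured; it differs from compound 1 by 4-(tert-butyl)phenyl in place of 2-chlorophenyl on a saturated chain carbon bound to an oxygen on an unsaturated carbon. For the measured compounds named here, no measured pair shows a change of this kind, so the step from compound 1 to compound 3 is expected to be small, a 1.4-fold higher number from compound 1 to compound 3 (0.13 log units; within the scatter), in no firm direction and within the usual scatter. Compound 3 is therefore expected to give about 1500 nM, somewhere between 300 nM and 8000 nM.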

Compound 3, half-maximal effective concentration: 7900 nM
Beside the measured number, compound 3's estimate is 5.3-fold (0.72 log units) below it, and the stated range covers the measured number.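

Swapping 2-chlorophenyl for 4-(tert-butyl)phenyl on a saturated chain carbon bound to an oxygen on an unsaturated carbon gives a 7.2-fold higher number from compound 1 to compound 3 (0.86 log units; beyond the scatter) in this assay, so the group held at this place does affect the read-out. Among the compounds shown here, this is the first step between compounds that differ in only one place. Nothing shown gives a reason for it. Going by these compounds, whether the loss of the chlorine or the arrival of the tert-butyl drives the step stays open. So does how a plain phenyl or a pyridine ring would behave here.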